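Working notes: chloro removal on a two-compound series

The source may report more compounds than this note shows. Statements on the series, on what has been measured and on what is new or still open speak of the compounds shown alone.

Measured in a functional assay on IGROV-1 cells (Homo sapiens) for cytotoxicity, read by sulforhodamine B assay, with a stated time of 48 h (a lower number here means a stronger inhibitor of growth, a higher number a weaker inhibitor of growth), so far:
compound 1 `Nc1nc(Cl)c2ncn(Cc3ccccc3CCl)c2n1` — > 100000 nM
compound 2 `ClCc1ccccc1Cn1cnc2nc(Cl)nc(Cl)c21` — 5240 nM

Compound 1 reports only a limit in this assay, > 100000 nM. Among the measured compounds shown here, compound 2 therefore carries the only real number, 5240 nM; the other entry is the limit of > 100000 nM in this assay, at which 1 of the 2 values shown sits. For the measured compounds named here, no pair of measured compounds differs in a single place, so no measured step is available to calibrate the series, and compound 2 stands alone as the sole numeric anchor.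

The next compound is compound 3 `ClCc1ccccc1Cn1cnc2ncnc(Cl)c21`, which differs from compound 2 by hydrogen in place of chloro on an aromatic carbon.

Going by the values given here, with no measured step to lean on, the step from compound 2 to compound 3 in this assay is expected to be a moderate loss of growth inhibition, somewhat beyond the usual scatter, a 2.3-fold higher number from compound 2 to compound 3 (0.36 log units; beyond the scatter). Compound 3 is accordingly estimated at 12000 nM, with a plausible range from 3000 nM to 50000 nM.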

Compound 3, concentration for total growth inhibition: 22900 nM
The estimate for compound 3 lay 1.9-fold (0.28 log units) below the measured number, within the range that was stated.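

In this assay, among the compounds shown here, hydrogen in place of chloro on an aromatic carbon between two ring nitrogen atoms gives a 4.4-fold higher number from compound 2 to compound 3 (0.64 log units; beyond the scatter) and is the only measured step. This position therefore responds to the change: losing this one chlorine atom weakens growth inhibition beyond the scatter, yet compound 3, which keeps the other chloro group, still gives a real number, 22900 nM, and not a limit. Nothing measured here accounts for the size of this step.

Going by these compounds, whether the loss is specific to chloro stays open: a methyl or a methoxy group on the same carbon could fall near either compound 2 or compound 3. Also open, on these data alone, is whether the same step would appear on the core of compound 1.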